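Swapping the Aryl Group on a Sulfonyl Sulfur

A few compounds are considered here, and "the series" means these few. Any claim that something is new, unique, unknown or untested is made for them only; others in the source may bear on it.

- compound 1 `CC(C)C(NS(=O)(=O)c1ccccc1Br)C1=CC(=O)c2c(O)ccc(O)c2C1=O`: 340 nM
- compound 2 `CC(NS(=O)(=O)c1ccc(Cl)cc1)C1=CC(=O)c2c(O)ccc(O)c2C1=O`: 250 nM

In a functional assay on HL-60 cells (Homo sapiens) for cytotoxicity, read by MTT assay (a higher number here means a weaker inhibitor, a lower number a stronger inhibitor), compound 2 gives 250 nM, which lies within the usual scatter of compound 1 at 340 nM. Compound 3 `CC(NS(=O)(=O)c1ccccc1Br)C1=CC(=O)c2c(O)ccc(O)c2C1=O` differs from compound 2 in one place: 2-bromophenyl in place of 4-chlorophenyl on a sulfonyl sulfur. In words, it has 2-bromophenyl in place of 4-chlorophenyl on a sulfonyl sulfur. Among the compounds with values here, no measured pair shows this swap alone, so the evidence is thin. In this assay no step beyond the scatter is expected. The estimated change is a 1.1-fold higher number from compound 2 to compound 3 (0.05 log units; within the scatter). The expected value for compound 3 is 280 nM, with an estimated range of 110 nM to 700 nM.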

Compound 3, half-maximal inhibitory concentration: 120 nM
Beside the measured number, compound 3's estimate is 2.3-fold (0.37 log units) above it; low and high end bracket the measured number.
By their numbers in this assay, from the lowest: compound 3; then compounds 2 and 1 (each within the scatter of the next).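

The aryl group on the sulfonyl sulfur matters in this assay: 2-bromophenyl in place of 4-chlorophenyl moves the number beyond the scatter (a 2.1-fold lower number from compound 2 to compound 3 (0.32 log units; beyond the scatter)). The saturated chain carbon matters as well, with methyl in place of isopropyl also giving a step beyond the scatter (a 2.8-fold lower number from compound 1 to compound 3 (0.45 log units; beyond the scatter)). Nothing at hand explains either step. On these data alone, the aryl swap changes both the halogen and its place on the ring, so the contribution of each stays open. A 2-chlorophenyl group would separate them, and an ethyl group would fill in the chain series.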